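Amide substituent variation in a carrageenan-type paw edema series

A few compounds are considered here, and "the series" means these few. Any claim that something is new, unique, unknown or untested is made for them only; others in the source may bear on it.

Of the compounds shown here, three sharing one core have been measured. Compound 1 `COc1cc2c(cc1OC)C(CC(=O)O)CC2` carries a carboxylic acid, compound 2 `COc1cc2c(cc1OC)C(CC(N)=O)CC2` the plain amide and compound 3 `COc1cc2c(cc1OC)C(CC(=O)NC(C)(C)C)CC2` the amide bearing a tert-butyl group on nitrogen. In a functional assay on the whole organism (strain Wistar) for inhibition, with Rattus norvegicus as the target, read by paw edema, with stated times of 60 min and 4 h, at a dose of 100 mg/kg by the oral route (a lower number here means less inhibition, a higher number more inhibition at the dose given (going by the name of the read-out)), compound 1 gives 23.9%, compound 2 gives 31.3% and compound 3 gives 32.8%. Compound 3 stands at the top of these three numbers, yet both of its steps, a number 8.9 percentage points higher from compound 1 to compound 3 (within the scatter) and a number 1.5 percentage points higher from compound 2 to compound 3 (within the scatter), fall within the scatter, as does a number 7.4 percentage points higher from compound 1 to compound 2 (within the scatter), so the three compounds cannot truly be told apart.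

Compound 4 `COc1cc2c(cc1OC)C(CC(=O)NC1CCCC1)CC2` has not been measured. Its change from compound 3 is cyclopentyl in place of tert-butyl on an amide-type nitrogen. For the measured compounds named here, the only measured step touching the same nitrogen is a number 1.5 percentage points higher from compound 2 to compound 3 (within the scatter), a small one, and no step from tert-butyl to cyclopentyl is known. Therefore no step beyond the scatter is expected. Compound 4 is expected to give 33%, with a range from 22% to 44%. This estimate means an expected step of a number 0.2 percentage points higher from compound 3 to compound 4 (within the scatter), within the scatter.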

Compound 4, a percentage reported as inhibition, in the whole organism at one dose (the size of the read-out at that dose, not a potency): 45.3%
Beside the measured number, compound 4's estimate is 12.3 percentage points below it, outside the stated range (above it).
By their numbers in this assay, from the lowest: compounds 1, 2 and 3 (each within the scatter of the next); then compound 4.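

For the compounds shown here, on the amide-type nitrogen, the choice of substituent now clearly matters in this assay: cyclopentyl in place of tert-butyl gives a number 12.5 percentage points higher from compound 3 to compound 4 (beyond the scatter) and is the first change at this position to clear the scatter. Compound 4 also separates from the plain amide, with a number 14 percentage points higher from compound 2 to compound 4 (beyond the scatter) as the step, and from the carboxylic acid, with a number 21.4 percentage points higher from compound 1 to compound 4 (beyond the scatter) as the step, whereas compounds 1, 2 and 3 could not be told apart. No measurement here explains the difference between cyclopentyl and tert-butyl.

Still open, as far as these compounds go, is whether the gain depends on this ring size, since cyclobutyl or cyclohexyl on the same nitrogen could compare either way. An open pentyl chain there would show whether a ring is needed at all.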